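The source may report more compounds than this note shows. Statements on the series, on what has been measured and on what is new or still open speak of the compounds shown alone.

Measured so far:
compound 1 `COc1cc(C)cc(-c2c(-c3ccnc(-c4ccc(C(C)=O)cc4)c3)cnn2CC#N)c1` — 102%
compound 2 `COc1cc(C)cc(-c2nn(CC#N)cc2-c2ccnc(-c3ccc(N(C)C)cc3)c2)c1` — 102%

In a functional assay on MOLT-4 cells (Homo sapiens) for cytotoxicity, read by sulforhodamine B assay, with a stated time of 48 h, tested at 0.001 uM (on this read-out higher numbers stand for a weaker effect at the one concentration tested and lower numbers for a stronger effect), compound 1 gives 102%, a read-out at the very top of the scale, meaning that at the single concentration tested it leaves the cells essentially untouched. Compound 2 sits level with it, at 102%, so the two cannot be told apart within the usual scatter.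

The step now followed leads from compound 1 to compound 3 `COc1cc(C)cc(-c2c(-c3ccnc(-c4ccc(N(C)C)cc4)c3)cnn2CC#N)c1`. The structural change is dimethylamino in place of acetyl on an aromatic carbon. Going by the values given here, no measured pair shows this exact change, so its effect is open. Compound 2, which also carries a dimethylamino group, gives 102%, and on that basis the step from compound 1 to compound 3 is expected to be a number 2 percentage points lower from compound 1 to compound 3 (within the scatter), that is, nothing beyond the scatter. Compound 3 is therefore estimated at 100%, within 88% to 112%.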

Compound 3, a percentage reported as activity, at one concentration (the size of the read-out at that concentration, not a potency): 96%
Compound 3: the middle estimate sits 4 percentage points above what was measured; the measured number falls inside the stated range.
By their numbers in this assay, from the lowest: compounds 3, 1 and 2 (each within the scatter of the next).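

Going from 4-acetylphenyl to 4-(dimethylamino)phenyl gives a number 6 percentage points lower from compound 1 to compound 3 (within the scatter) in this assay. Going by these compounds alone, this is the first direct comparison of two compounds that differ in only one place, and it shows that at this single concentration, the read-out does not separate dimethylamino from acetyl on this aromatic carbon. No independent measurement is available to bear on this result.

Going by these compounds, whether a carboxylic acid or a primary amine on the same aromatic carbon would shift the read-out beyond the scatter remains open. Also open, on these data alone, is whether acetyl and dimethylamino would still be indistinguishable at concentrations other than the one tested here.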